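Styrylated terpene series: aryl substituent swap at the para position

This account rests on a few compounds, and the source may have more. Where it says the series, first, only, none or still open, it means among the compounds named here.

Measured so far in a functional assay on SEM cells (Homo sapiens) for cytotoxicity, with a stated time of 72 h; on this read-out lower numbers stand for an effect already at smaller amounts and higher numbers for an effect only at larger amounts of compound:
- compound 1, `C=C[C@@](C)(/C=C/c1ccc(OCc2ccccc2)cc1)CCC=C(C)C`: > 36600 nM
- compound 2, `C=C[C@@](C)(/C=C/c1ccc(O)c(/C=C/c2ccc(F)cc2)c1)CCC=C(C)C`: > 36600 nM

In this assay compound 1 reports only a limit, not a number. Compound 2 likewise reports only a limit. Both measured values therefore sit at the limit of > 36600 nM in this assay, at which 2 of the 2 values shown sit, and compound 1 stands with the rest of the shown material rather than apart from it. Going by the values given here, no step between two measured compounds is available.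

Compound 3, `C=C[C@@](C)(/C=C/c1ccc(-c2ccc(Cl)c(Cl)c2)cc1)CCC=C(C)C`, is not yet measured. Compared with compound 1 it carries 3,4-dichlorophenyl in place of benzyloxy on an aromatic carbon. With only limits on record, any shift is an expectation without a measured anchor. A modest step toward an effect at smaller amounts is expected, an at least 1.4-fold lower number from compound 1 to compound 3 (0.16 log units; that floor lies within the scatter), but not beyond the usual scatter with confidence. For compound 3 the expected value is 25000 nM, within a range from 8000 nM to 60000 nM.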

Compound 3, half-maximal effective concentration: > 36600 nM
Compound 3: only a limit was reported (the forecaster's own chance of this, stated with the estimate: 55%); at least 1.4-fold (0.16 log units) between middle value and limit.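

Compound 1 and compound 3 each report only a limit in this assay, so no step can be read for 3,4-dichlorophenyl in place of benzyloxy: the limit of > 36600 nM in this assay, at which 3 of the 3 values shown sit.

The compounds shown leave open what size of effect, if any, either group gives in this assay.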